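The source may hold more compounds than are shown below. What is called first, only, known or untested is meant among the compounds shown, and "the series" means these compounds.

Measured compounds:
- compound 1, `CCc1cnc(N2CCC(n3ncc4cc(-c5ccc(S(C)(=O)=O)cc5)ncc43)CC2)nc1`: 260 nM
- compound 2, `CC(C)OC(=O)N1CCC(n2ncc3cc(-c4ccc(S(C)(=O)=O)cc4)ncc32)CC1`: 1510 nM
- compound 3, `CCNC(=O)c1cc(F)c(-c2cc3nnn(C4CCN(c5ncc(CC)cn5)CC4)c3cn2)cc1F`: 240 nM

In a physicochemical assay for solubility, read by HPLC, in phosphate buffer, measured as thermodynamic solubility, with a stated time of 24 h, at pH 6.8 (a lower number here means a less soluble compound, a higher number a more soluble compound), compound 1 gives 260 nM and compound 2 gives 1510 nM. The change between them, (isopropoxycarbonyl in place of 5-ethylpyrimidin-2-yl on an amine nitrogen in a ring), made a 5.8-fold higher number from compound 1 to compound 2 (0.76 log units; beyond the scatter). Compound 3 has a different core; the difference between the two cores is not broken down here. In this assay compound 3 gives 240 nM, a number close to that of compound 1. Compound 4, `CCNC(=O)c1cc(F)c(-c2cc3nnn(C4CCN(C(=O)OC(C)C)CC4)c3cn2)cc1F`, is not yet measured; it carries the same change as compound 2 does, (isopropoxycarbonyl in place of 5-ethylpyrimidin-2-yl on an amine nitrogen in a ring), on a place described in the same words. Because the earlier step of a 5.8-fold higher number from compound 1 to compound 2 (0.76 log units; beyond the scatter) was beyond the scatter, compound 4 is expected to show a step of about a 5.4-fold higher number from compound 3 to compound 4 (0.73 log units; beyond the scatter) in this assay. Compound 4 is therefore estimated at 1300 nM, between 500 nM and 3500 nM.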

Compound 4, solubility: 5500 nM
For compound 4 the middle estimate is 4.2-fold (0.63 log units) below the measured one, and the stated range ends below it.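

In this assay putting isopropoxycarbonyl in place of 5-ethylpyrimidin-2-yl on the ring amine nitrogen gives a 5.8-fold higher number from compound 1 to compound 2 (0.76 log units; beyond the scatter) on one core and a 23-fold higher number from compound 3 to compound 4 (1.36 log units; beyond the scatter) on the other core. The direction of the change therefore carried over between these two cores, but its size did not, with the second step the larger, and two pairs cannot show how it would behave on a third core. No measurement shown here accounts for the difference in size between the two steps.

Still open, on these data alone, is how the number would move with other groups on the same nitrogen, such as ethoxycarbonyl or acetyl. Also open, as far as these compounds go, is whether a carboxylic acid or an amine there would follow the same direction on both cores.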